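The source may hold more compounds than are shown below. What is called first, only, known or untested is meant among the compounds shown, and "the series" means these compounds.

Measured so far in a functional assay on L1210 cells (Mus musculus) for antiproliferative activity, read by cell counting, with a stated time of 96 h (a lower number here means a stronger inhibitor, a higher number a weaker inhibitor), on the series:
compound 1 `CCOc1ccccc1NC(C)=C1C(=O)CC(c2ccccc2)CC1=O` gives 190 nM
compound 2 `CC(Nc1ccccc1Oc1cccc(N)c1)=C1C(=O)CC(c2ccccc2)CC1=O` gives 53 nM

Compound 2 at 53 nM holds the lower of the two numbers. Compound 3 `COc1cccc(Oc2ccccc2NC(C)=C2C(=O)CC(c3ccccc3)CC2=O)c1` differs from it by methoxy in place of amino on an aromatic carbon (methoxy in place of amino on an aromatic carbon, meta to a large group). Among the measured compounds shown here, the one measured step bearing on this is a 3.6-fold lower number from compound 1 to compound 2 (0.55 log units; beyond the scatter) and it is modest, so for compound 3 a smaller step toward a higher number is expected, perhaps within the scatter. For the measured compounds named here, no measured step isolates the amino group. The expected change is a 1.4-fold higher number from compound 2 to compound 3 (0.15 log units; within the scatter) in this estimate. Compound 3 is estimated at 75 nM with an expected range from 28 nM to 200 nM in this assay for now.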

Compound 3, half-maximal inhibitory concentration: 58 nM
Compound 3: the middle estimate sits 1.3-fold (0.11 log units) above what was measured; the measured number falls inside the stated range.
By their numbers in this assay, from the lowest: compounds 2 and 3 (each within the scatter of the next); then compound 1.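

Methoxy in place of amino on the aromatic carbon gives a 1.1-fold higher number from compound 2 to compound 3 (0.04 log units; within the scatter), so removing the hydrogen-bond donor of the amino group moves the number by no more than the scatter. The advantage over ethyl on the oxygen persists with 3-methoxyphenyl, at a 3.3-fold lower number from compound 1 to compound 3 (0.52 log units; beyond the scatter), and so does not depend on the amino group in these compounds. No supporting data offer an explanation for either step.

Open, on these data alone, is whether an unsubstituted phenyl on that oxygen would hold this level. Also open, as far as these compounds go, is whether a hydroxyl or a carboxylic acid in place of methoxy would do so.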